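The compounds below may be only part of what the source reports. "The series", "measured", "known", "first", "only" and "open" are said of these compounds alone.

In a functional assay on MCF7 cells (Homo sapiens) for inhibition, read by resazurin assay, with a stated time of 72 h (a higher number here means a weaker inhibitor, a lower number a stronger inhibitor), compound 3 `CCSc1ccc(C2CC(=O)N2c2cc(OC)c(OC)c(OC)c2)cc1` gives 141 nM, and it carries only hydrogen on the saturated ring carbon that varies in this small set. On that carbon, compound 1 `CCSc1ccc(C2C(Oc3ccccc3)C(=O)N2c2cc(OC)c(OC)c(OC)c2)cc1` has phenoxy and gives 210 nM, while compound 2 `CCSc1ccc(C2C(O)C(=O)N2c2cc(OC)c(OC)c(OC)c2)cc1` has hydroxy and gives 6 nM. Compound 3 therefore stands close to compound 1 and far from compound 2.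

Compound 4 `C=CC1C(=O)N(c2cc(OC)c(OC)c(OC)c2)C1c1ccc(SCC)cc1` changes the same carbon: vinyl in place of hydrogen on a saturated ring carbon. Among the compounds with values here, two measured steps bear on this change. Putting hydrogen in place of phenoxy gave a 1.5-fold lower number from compound 1 to compound 3 (0.17 log units; within the scatter), whereas putting hydrogen in place of hydroxy gave a 24-fold higher number from compound 2 to compound 3 (1.37 log units; beyond the scatter). Only the hydroxy compound stands apart, and vinyl has no hydroxy, so the phenoxy step seems the closer guide. No other carbon group has been measured at this place, so the uncertainty is wide.

A small move towards a lower number is expected in this assay, with the estimated step being a 1.8-fold lower number from compound 3 to compound 4 (0.25 log units; within the scatter). For compound 4 the estimated value is 80 nM, with an expected range from 15 nM to 350 nM.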

Compound 4, half-maximal inhibitory concentration: 181 nM
Beside the measured number, compound 4's estimate is 2.3-fold (0.35 log units) below it, within the range that was stated.
By their numbers in this assay, from the lowest: compound 2; then compounds 3, 4 and 1 (each within the scatter of the next).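

In this assay, vinyl in place of hydrogen on this saturated ring carbon gives a 1.3-fold higher number from compound 3 to compound 4 (0.11 log units; within the scatter), and vinyl in place of phenoxy gives a 1.2-fold lower number from compound 1 to compound 4 (0.06 log units; within the scatter), so hydrogen, phenoxy and this small carbon group all give numbers within the scatter of one another. Vinyl in place of hydroxy gives a 30-fold higher number from compound 2 to compound 4 (1.48 log units; beyond the scatter), which leaves compound 2 alone among the four, with its steps to all three others beyond the scatter. No measured evidence here accounts for the separate place of the hydroxy compound.

The compounds shown leave open whether an amine or a methoxy group on this carbon would give a number near that of compound 2 or near those of the other three. They also leave open whether a longer chain or a saturated ethyl group would stay with compound 4.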